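Series notes: from compound 2 to compound 4

The source may hold more compounds than are shown below. What is called first, only, known or untested is meant among the compounds shown, and "the series" means these compounds.

Within the data shown here, in a functional assay on A549 cells (Homo sapiens) for antiproliferative activity, read by sulforhodamine B assay, with a stated time of 48 h (on this read-out lower numbers stand for stronger inhibition and higher numbers for weaker inhibition), compound 2 (`COc1cc(C=C(C(=O)/C=C/c2cccc(OC)c2OC)C(=O)/C=C/c2cccc(OC)c2OC)ccc1O`) gives 130 nM, the lowest of the three numbers so far. Compound 1 (`COc1cccc(/C=C/C(=O)C(=Cc2ccc(F)cc2)C(=O)/C=C/c2cccc(OC)c2OC)c1OC`) gives 340 nM, and compound 3 (`COc1cc(OC)c(C=C(C(=O)/C=C/c2cccc(OC)c2OC)C(=O)/C=C/c2cccc(OC)c2OC)c(OC)c1`) gives 630 nM. These two lie within the scatter of each other, as a 1.9-fold higher number from compound 1 to compound 3 (0.27 log units; within the scatter) shows.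

Compound 4 (`COc1cccc(/C=C/C(=O)C(=Cc2ccc(OC)c(OC)c2OC)C(=O)/C=C/c2cccc(OC)c2OC)c1OC`) has not been measured. It departs from compound 2 in one place, on a double-bonded chain carbon bound to a double-bonded chain carbon, with 2,3,4-trimethoxyphenyl in place of 4-hydroxy-3-methoxyphenyl on a double-bonded chain carbon bound to a double-bonded chain carbon.

Among the measured compounds shown here, the closest precedent is a 4.8-fold higher number from compound 2 to compound 3 (0.69 log units; beyond the scatter), where 4-hydroxy-3-methoxyphenyl also leaves and a differently arranged trimethoxyphenyl, 2,4,6-trimethoxyphenyl, enters. The step of a 2.6-fold lower number from compound 1 to compound 2 (0.42 log units; beyond the scatter) points the same way, since the number falls when 4-hydroxy-3-methoxyphenyl replaces 4-fluorophenyl. Both measured replacements of this group in compound 2 therefore sit higher, and a rise beyond the scatter is the likely direction. For the measured compounds named here, no measured compound carries 2,3,4-trimethoxyphenyl, so the size stays uncertain.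

A modest rise of a 3.1-fold higher number from compound 2 to compound 4 (0.49 log units; beyond the scatter) is expected in this assay. For compound 4 the estimated value is 400 nM, with an expected range of 150 nM to 1000 nM.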

Compound 4, half-maximal inhibitory concentration: 260 nM
For compound 4 the middle estimate is 1.5-fold (0.19 log units) above the measured one, and the stated range covers the measured number.
By their numbers in this assay, from the lowest: compounds 2, 4, 1 and 3 (each within the scatter of the next, the first and the last beyond it).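

In this assay, the step to 2,3,4-trimethoxyphenyl on a double-bonded chain carbon bound to a double-bonded chain carbon, with a 2.0-fold higher number from compound 2 to compound 4 (0.30 log units; within the scatter) and a 1.3-fold lower number from compound 1 to compound 4 (0.12 log units; within the scatter), leaves compound 4 within the scatter of both compound 2 and compound 1, so among these compounds a hydrogen-bond donor on this aryl group is not needed to stay in that range. The two trimethoxyphenyl groups carry the same atoms yet are separated by a 2.4-fold lower number from compound 3 to compound 4 (0.38 log units; beyond the scatter), which shows that at this position the arrangement of the three methoxy groups counts, not only their presence. Nothing measured explains either observation, and no supporting data bear on why the arrangement matters here.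

The compounds shown leave open how this position responds to a basic amine such as dimethylamino or to a carboxylic acid on the aryl group, since every group seen here is a phenyl carrying only methoxy, hydroxy or fluoro. They also leave open whether the difference between the two trimethoxyphenyl arrangements persists when the rest of the shared core is changed.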